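Chloro on the core ring: compound 3 to compound 4

The compounds below may be only part of what the source reports. "The series", "measured", "known", "first", "only" and "open" are said of these compounds alone.

Values in a functional assay on cells (Cancer cell lines, Homo sapiens) for cytotoxicity, with a stated time of 48 h (a lower number here means a stronger inhibitor of growth, a higher number a weaker inhibitor of growth), for the measured compounds:
compound 1 `O=C1Nc2ccccc2/C1=C\c1c(Cl)n(Cc2ccccc2)c2ccccc12` gives 64600 nM
compound 2 `COc1cc2c(/C=C3/C(=O)Nc4cccc(Cl)c43)c(Cl)n(Cc3cc(OC)c(OC)c(OC)c3)c2cc1C` gives 15100 nM
compound 3 `O=C1Nc2ccccc2/C1=C\c1c(Cl)n(CCCc2ccccc2)c2ccccc12` gives 72400 nM

For the measured compounds named here, compound 3 stands at the highest number of the three, but the one measured step here, a 1.1-fold higher number from compound 1 to compound 3 (0.05 log units; within the scatter), lies within the scatter, so these two compounds are indistinguishable; only compound 2 stands clearly lower, beyond the scatter, and compound 2 differs from compound 3 in several places at once, so no single step can be read from that pair.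

Compound 4 `O=C1Nc2ccc(Cl)cc2/C1=C\c1c(Cl)n(CCCc2ccccc2)c2ccccc12` differs from compound 3 only by chloro in place of hydrogen on an aromatic carbon, the new group sitting meta to a fused ring and para to a fused ring on the core. Going by the values given here, no measured step in this set changes a hydrogen for a chloro alone; the one measured step, from compound 1 to compound 3, concerns the chain on the aromatic nitrogen and bears on nothing here. The expectation therefore rests on little: a step of a 1.8-fold lower number from compound 3 to compound 4 (0.26 log units; within the scatter) in this assay is estimated, towards a somewhat lower number, with a wide range. Compound 4 is expected at 40000 nM, between 15000 nM and 100000 nM.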

Compound 4, concentration for total growth inhibition: 9120 nM
Compound 4: middle estimate off by 4.4-fold (0.64 log units), on the high side; the measured number lies below the stated range.
By their numbers in this assay, from the lowest: compounds 4 and 2 (each within the scatter of the next); then compounds 1 and 3 (each within the scatter of the next).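

In this assay, for the compounds shown here, chloro in place of hydrogen on an aromatic carbon gives a 7.9-fold lower number from compound 3 to compound 4 (0.90 log units; beyond the scatter), which is the first single-place change to lie beyond the scatter; the earlier step on the chain at the aromatic nitrogen, a 1.1-fold higher number from compound 1 to compound 3 (0.05 log units; within the scatter), lies within it. Going by these compounds alone, this aromatic carbon of the shared core, meta to a fused ring and para to a fused ring, is therefore a place where one added heavy atom clearly moves the number for growth inhibition, although this rests on the single pair of compound 3 and compound 4. Nothing available here explains the size of this step.

It remains open whether chloro at this carbon gives a step of like size when the chain on the aromatic nitrogen is that of compound 1, since that pairing cannot be read from the compounds shown. Also open, from the compounds shown here alone, is whether the step is particular to chloro or is shared by other groups at the same carbon, such as bromo, an amine or a carboxylic acid.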